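Replacing the aryl group on a thiazolidinone-like scaffold

This account rests on a few compounds, and the source may have more. Where it says the series, first, only, none or still open, it means among the compounds named here.

Within the data shown here, compound 2 `CCOC(=O)C1=C(Nc2ccccc2)S/C(=C\c2ccc(Br)c(O)c2)C1=O` stands lowest of the two numbers so far in a functional assay on MCF7 cells (Homo sapiens) for inhibition, read by MTT assay, with a stated time of 72 h, tested at 10 uM; a lower number here means less inhibition, a higher number more inhibition at the concentration tested (going by the name of the read-out). Compound 1 `CCOC(=O)C1=C(Nc2ccccc2)S/C(=C\c2ccc(O)c(O)c2)C1=O` gives 38.1% in this assay, while compound 2 gives 16.4%, a step of a number 21.7 percentage points lower from compound 1 to compound 2 (beyond the scatter). Compound 3 `CCOC(=O)C1=C(Nc2ccccc2)S/C(=C\c2cccc(C(=O)O)c2)C1=O` has not yet been measured. It differs from compound 2 by 3-carboxyphenyl in place of 4-bromo-3-hydroxyphenyl on a double-bonded chain carbon bound to a double-bonded ring carbon. Among the measured compounds shown here, the only measured step that bears on this change is the one from compound 1 to compound 2, which also alters the substitution on the same aryl ring and gave a modest fall; it shows that the read-out responds to changes on that ring, but it does not show the direction for a carboxy group in the 3-position. With so little to go on, a step in this assay near the scatter in either direction, a number 8.6 percentage points higher from compound 2 to compound 3 (within the scatter), is expected. Compound 3 is therefore estimated to give 25%, within a range from 5% to 50%.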

Compound 3, a percentage reported as inhibition, at one concentration (the size of the read-out at that concentration, not a potency): < 10%
Compound 3: a limit, no number (the forecaster's own chance of this, stated with the estimate: 0%); at least 15 percentage points between middle value and limit.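

The change to 3-carboxyphenyl on a double-bonded chain carbon bound to a double-bonded ring carbon gives a number at least 28.1 percentage points lower from compound 1 to compound 3 (beyond the scatter) in this assay, so among the three compounds, both replacements of the 3,4-dihydroxyphenyl of compound 1 come with less inhibition. Compound 3 is a limit and not a number: the limit of < 10% in this assay, at which 1 of the 3 values shown sits. Set against the 4-bromo-3-hydroxyphenyl group, the change gives a number at least 6.4 percentage points lower from compound 2 to compound 3 (that floor lies within the scatter), and so this step does not separate compound 3 from compound 2.

The compounds shown leave open how far inhibition lies under the limit for compound 3, and so whether the carboxylic acid truly stands lower than the 4-bromo-3-hydroxyphenyl group. They also leave open what an amine or a methoxy group on the same ring would give.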